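Chain amine replacing the butyl tail on the shared core

This account rests on a few compounds, and the source may have more. Where it says the series, first, only, none or still open, it means among the compounds named here.

In a functional assay on DU-145 cells (Homo sapiens) for cytotoxicity, read by MTT assay, with a stated time of 2 days (on this read-out lower numbers stand for stronger inhibition and higher numbers for weaker inhibition), compound 1 `CCCCNc1nc(NCc2ccco2)c2ccccc2n1` gives 4990 nM. For the measured compounds named here, only one other number exists: compound 3 `CCCCNc1nc(NCc2ccco2)c2cc(F)ccc2n1` gives 5910 nM in this assay, and the step of a 1.2-fold higher number from compound 1 to compound 3 (0.07 log units; within the scatter) lies within the scatter, so the two compounds cannot be ordered against each other. Compound 2 `CCCCNc1nc(NCc2ccco2)c2cccc(F)c2n1` gives "not determined" (no result reported) in this assay, that is, no result.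

Compound 4 `CCN(CC)CCNc1nc(NCc2ccco2)c2ccccc2n1` differs from compound 1 by diethylamino in place of ethyl on a saturated chain carbon, two bonds along the chain from a nitrogen on an aromatic ring. Going by the values given here, no measured step touches this chain. Among the compounds with values here, the only step in hand, a 1.2-fold higher number from compound 1 to compound 3 (0.07 log units; within the scatter), concerns a fluoro in place of hydrogen on an aromatic carbon and says nothing about the butylamino side of the core. The expectation for compound 4 therefore rests on compound 1 alone, with wide uncertainty rather than a directed change; the step is expected as a 1.1-fold lower number from compound 1 to compound 4 (0.04 log units; within the scatter), no larger than the scatter. Compound 4 is thus estimated at 4500 nM in this assay, with a range from 1200 nM to 16000 nM.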

Compound 4, half-maximal inhibitory concentration: > 100000 nM
Compound 4 gave a limit, no number (the forecaster's own chance of this, stated with the estimate: 10%); at least 22-fold (1.34 log units) between middle value and limit.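

For the compounds shown here, replacing butylamino with (2-(diethylamino)ethyl)amino on the shared core gives an at least 20-fold higher number from compound 1 to compound 4 (1.30 log units; beyond the scatter), the first step beyond the scatter, whereas the fluoro change gave only a 1.2-fold higher number from compound 1 to compound 3 (0.07 log units; within the scatter). This chain position therefore responds strongly to the change, which the fluoro pair could not show, although this rests on a single pair. The reading for compound 4 in this assay is a limit of the assay and not a number: the limit of > 100000 nM in this assay, at which 1 of the 4 values shown sits.

Still open, on these data alone, is whether the step follows from the diethylamino nitrogen or from the added carbons on the chain, a question that a plain hexyl chain at this position would address. A dimethylamino or morpholine group on the same chain would show how far the step depends on the particular amine.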